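Bromo entering beside methoxy on the pyridine of compound 3

The compounds below may be only part of what the source reports. "The series", "measured", "known", "first", "only" and "open" are said of these compounds alone.

Measured so far in a functional assay on HEK293 cells for agonist activity at Neuronal acetylcholine receptor; alpha3/beta4 (Homo sapiens), read by FLIPR; a lower number here means that less compound is needed, a higher number that more compound is needed for the effect:
compound 1, `Brc1cc(N2CC[C@H]3CN[C@H]3C2)cnc1Br`, gives 8.2 nM
compound 2, `N#Cc1cncc(N2CC[C@H]3CN[C@H]3C2)c1`, gives 1000 nM
compound 3, `COc1cncc(N2CC[C@H]3CN[C@H]3C2)c1`, gives 180 nM

Compound 3 stands second highest of the three numbers. Its nearest neighbour is compound 2, whose value lies higher; compound 1 lies furthest away, with a far lower number. Going by the values given here, the one single-point step measured so far is a 5.6-fold lower number from compound 2 to compound 3 (0.74 log units; beyond the scatter), a modest change for swapping a substituent on the aromatic ring.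

Compound 4, `COc1cc(N2CC[C@H]3CN[C@H]3C2)cnc1Br`, is the next member. Relative to compound 3 the change is bromo in place of hydrogen on an aromatic carbon. Among the compounds with values here, no measured step covers a bromo entering at this place; compound 1 carries bromo twice and sits at the low end of the series, but it differs from compound 3 in two places, so only its value can be compared. On that basis a lowering of the number for compound 4 in this assay is expected, estimated as a 4.5-fold lower number from compound 3 to compound 4 (0.65 log units; beyond the scatter), with wide uncertainty. Compound 4 is thus expected to give about 40 nM, in the range 10 nM to 160 nM.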

Compound 4, half-maximal effective concentration: 8 nM
Compound 4: middle estimate off by 5.0-fold (0.70 log units), on the high side; the whole stated range lies above it.
By their numbers in this assay, from the lowest: compounds 4 and 1 (each within the scatter of the next); then compound 3; then compound 2.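

In this assay, going by these compounds alone, bromo in place of hydrogen on the aromatic carbon next to the ring nitrogen gives a 23-fold lower number from compound 3 to compound 4 (1.35 log units; beyond the scatter) and is the first measured step at this position, one of large size. With this bromo present, methoxy in place of the second bromo gives a 1.0-fold lower number from compound 1 to compound 4 (0.01 log units; within the scatter) and leaves the two values indistinguishable, so that second place tolerates either group in this pair. No measured evidence accounts for the size of the bromo step.

The compounds shown leave open whether chloro or methyl on this carbon would match bromo, and whether the low value holds with an amine or a carboxylic acid in place of methoxy. From the compounds shown here alone, whether bromo with hydrogen in place of methoxy reaches the same level also remains open.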